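The source may hold more compounds than are shown below. What is called first, only, known or untested is meant among the compounds shown, and "the series" means these compounds.

Of the compounds shown here, three in this set have been measured, and one has not. Compound 1 `CCCCC[Se]c1nc(N)c2ccccc2n1` was tested in a functional assay on HTB-54 cells (Homo sapiens) for cytotoxicity, read by MTT assay, with a stated time of 72 h (a lower number here means a stronger inhibitor of growth, a higher number a weaker inhibitor of growth), where compound 1 gives 34600 nM. Compound 2 `C[Se]c1nc(N)c2ccccc2n1` gives 18000 nM in this assay, and compound 3 `CSc1nc(Nc2ccccc2)c2ccccc2n1` gives 55800 nM. Compound 2 thus holds the lowest of the three numbers; its number sits within the scatter of that of compound 1, whereas compound 3 shows a clearly higher number than compound 2. Among the compounds with values here, the one single-site step among the measured compounds is a 1.9-fold lower number from compound 1 to compound 2 (0.28 log units; within the scatter), which comes with hydrogen in place of butyl on a saturated chain carbon bound to a selenium atom.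

Compound 4 `Nc1nc([SeH])nc2ccccc12` differs from compound 2 as follows: hydrogen in place of methyl on a selenium. This change bears on the same selenium-bound chain as the step already seen, and because a 1.9-fold lower number from compound 1 to compound 2 (0.28 log units; within the scatter) stayed within the scatter, a step of no more than the scatter is expected here too. Compound 4 is therefore expected to give about 15000 nM in this assay, with an estimated range from 5000 nM to 45000 nM. The expected step is a 1.2-fold lower number from compound 2 to compound 4 (0.08 log units; within the scatter).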

Compound 4, concentration for 50% growth inhibition: 40 nM
For compound 4 the middle estimate is 380-fold (2.57 log units) above the measured one, outside the stated range (below it).
By their numbers in this assay, from the lowest: compound 4; then compounds 2, 1 and 3 (each within the scatter of the next, the first and the last beyond it).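

Within the data shown here, at this selenium, bound to an aromatic carbon, the earlier compounds showed only that exchanging one chain for another made no difference beyond the scatter. Compound 4 shows that removing the chain altogether is a different matter in this assay: hydrogen in place of methyl gives a 450-fold lower number from compound 2 to compound 4 (2.65 log units; beyond the scatter), and hydrogen in place of pentyl gives an 870-fold lower number from compound 1 to compound 4 (2.94 log units; beyond the scatter). Among these compounds, the large change therefore goes with a hydrogen on the selenium rather than with the length of the chain, and nothing available here explains why.

The compounds shown leave open whether a benzyl group or an acetic acid chain on the selenium would give a number close to those of the methyl and pentyl compounds or one close to that of compound 4. They also leave open whether a sulfur atom carrying hydrogen at this place, on the core of compound 4, would match the selenium compound.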